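Swapping the ring carbamate for an ethylpyrimidine on a full agonist

A few compounds are considered here, and "the series" means these few. Any claim that something is new, unique, unknown or untested is made for them only; others in the source may bear on it.

Compound 2 `CC(C)(C)OC(=O)N1CCC(CCCNc2ccc3c(c2)OCC3=O)CC1` is tested in a functional assay on CHO-K1 cells for agonist activity at Glucose-dependent insulinotropic receptor (Mus musculus), read by HTRF and cAMP accumulation, with a stated time of 30 min (on this read-out higher numbers stand for larger maximal responses and lower numbers for smaller maximal responses), where it gives 108%. Its closest companion, compound 1 `CC(C)(C)OC(=O)N1CCC(CCCNc2ccc3c(c2)OCS3(=O)=O)CC1`, gives 105% in this assay, and the gap between the two lies within the usual scatter, so neither can be set above the other. Compound 3 `CCc1cnc(N2CCC(CCCNc3ccc4c(c3)OCC4=O)CC2)nc1` differs from compound 2 by 5-ethylpyrimidin-2-yl in place of tert-butoxycarbonyl on an amine nitrogen in a ring. Because compound 2 already reaches 108%, the step from compound 2 to compound 3 is expected to be a number 8 percentage points lower from compound 2 to compound 3 (within the scatter), no larger than the scatter. Compound 3 is therefore estimated to give 100%, within 75% to 115%.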

Compound 3, largest response reached (Emax), in percent of the reference or control that the assay uses: 98%
Estimate against measurement, compound 3: 2 percentage points above; measured number inside the range.
By their numbers in this assay, from the lowest: compounds 3, 1 and 2 (each within the scatter of the next).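

Within this assay the swap of tert-butoxycarbonyl for 5-ethylpyrimidin-2-yl on the amine nitrogen in the ring gives a number 10 percentage points lower from compound 2 to compound 3 (within the scatter) and so shows that this nitrogen can carry an aromatic ring in place of the carbamate without a change beyond the scatter. Nothing available explains why the response holds across this change. Still open, going by these compounds, is how a pyrimidine without the ethyl group, a longer alkyl group on the pyrimidine, or a plain methyl on this nitrogen would compare.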